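The source may hold more compounds than are shown below. What is called first, only, known or untested is meant among the compounds shown, and "the series" means these compounds.

Compound 3 `C=CC(=O)Nc1cc(Nc2ncc(Cl)c(Nc3ccc(F)c(Cl)c3)n2)c(OC)cc1N1CCN(C)CC1` carries a 3-chloro-4-fluorophenyl on a nitrogen on an aromatic ring of the shared core. In a functional assay on NCI-H1975 cells (Homo sapiens) for inhibition, read by CellTiter-Glo, with a stated time of 72 h (a higher number here means a weaker inhibitor of growth, a lower number a stronger inhibitor of growth), compound 3 gives 100 nM, the second highest of three numbers. Compound 1 `C=CC(=O)Nc1cc(Nc2ncc(Cl)c(Nc3ccccc3S(=O)(=O)C(C)C)n2)c(OC)cc1N1CCN(C)CC1` gives 43 nM in this assay, and compound 2 `C=CC(=O)Nc1cc(Nc2ncc(Cl)c(Nc3cccc(C(F)(F)F)c3)n2)c(OC)cc1N1CCN(C)CC1` gives 260 nM. Compound 4 `C=CC(=O)Nc1cc(Nc2ncc(Cl)c(Nc3c(F)cccc3F)n2)c(OC)cc1N1CCN(C)CC1` differs from compound 3 in one place: 2,6-difluorophenyl in place of 3-chloro-4-fluorophenyl on a nitrogen on an aromatic ring. Going by the values given here, the steps that bear on exchanging the ring on that nitrogen are a 2.3-fold higher number from compound 1 to compound 3 (0.37 log units; beyond the scatter) and a 2.6-fold lower number from compound 2 to compound 3 (0.41 log units; beyond the scatter), both modest, so such exchanges have so far moved the number by modest amounts in either direction. The step of a 1.5-fold higher number from compound 3 to compound 4 (0.18 log units; within the scatter) is therefore expected to be small, with its direction uncertain. Compound 4 is estimated at 150 nM, within 60 nM to 400 nM.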

Compound 4, concentration for 50% growth inhibition: 130 nM
Estimate against measurement, compound 4: 1.2-fold (0.06 log units) above; low and high end bracket the measured number.
By their numbers in this assay, from the lowest: compound 1; then compounds 3, 4 and 2 (each within the scatter of the next, the first and the last beyond it).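

Putting 2,6-difluorophenyl on that nitrogen in place of 3-chloro-4-fluorophenyl gives no clear change in this assay: a 1.3-fold higher number from compound 3 to compound 4 (0.11 log units; within the scatter), and the comparison with 3-(trifluoromethyl)phenyl also stays inside the usual spread, with a 2.0-fold lower number from compound 2 to compound 4 (0.30 log units; within the scatter). Only the exchange of 2-(isopropylsulfonyl)phenyl separates clearly from the new compound, with a 3.0-fold higher number from compound 1 to compound 4 (0.48 log units; beyond the scatter). No measurement is available that explains these numbers.

The compounds shown leave open whether a phenyl ring bearing an amine or a carboxylic acid would fall with the halogen-bearing rings or with compound 1. They also leave open whether a smaller sulfonyl group, such as methylsulfonyl, would match compound 1.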